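The compounds below may be only part of what the source reports. "The series", "measured", "known", "first", "only" and "open" are said of these compounds alone.

Compound 1 `CC(C)CSc1nc(N)nc2c1ncn2/C=C1/CC1(CO)CO` and compound 2 `C=CCOc1nc(N)nc2c1ncn2/C=C1/CC1(CO)CO` share one core, but in an ADME assay on MOLT-3 cells (Homo sapiens) for cytotoxicity, with a stated time of 7 days (on this read-out lower numbers stand for higher toxicity in this test and higher numbers for lower toxicity in this test), compound 1 offers no number: "not determined" (no result reported). Compound 2 reads > 20000 nM, which is a limit of the assay and not a number. Compound 3 `CCOc1nc(N)nc2c1ncn2/C=C1/CC1(CO)CO` differs from compound 2 by a single change, methyl in place of vinyl on a saturated chain carbon bound to an oxygen on an aromatic ring: allyloxy becomes ethoxy. For the measured compounds named here, no measured pair of compounds shows what such a change does in this assay. The expected step that the limit leaves unreadable from compound 2 to compound 3 stays within the usual scatter, with no direction foreseen. Compound 3 is estimated at 25000 nM, with an expected range from 8000 nM to 60000 nM.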

Compound 3, half-maximal cytotoxic concentration: > 20000 nM
Compound 3 gave a limit, no number; the forecaster's own chance of this, stated with the estimate: 70%; the middle value lies beyond the limit too.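

No step can be read between compound 2 and compound 3, because both results stop at a limit of the assay and give no number: the limit of > 20000 nM in this assay, at which 2 of the 3 values shown sit. From the compounds shown here alone, what the change from allyloxy to ethoxy does in this assay stays open.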